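Swapping methoxy for pyridin-2-yl on compound 2

This account rests on a few compounds, and the source may have more. Where it says the series, first, only, none or still open, it means among the compounds named here.

In a functional assay on K562 cells (Homo sapiens) for cytotoxicity, read by fluorescence, with a stated time of 72 h (a higher number here means a weaker inhibitor, a lower number a stronger inhibitor), compound 1 (`CC(C)c1n[nH]c2c(NCc3ccc(-c4ccccn4)cc3)nc(NCCN)nc12`) gives 63 nM and compound 2 (`COc1ccc(CNc2nc(NCc3ccc(-c4ccccn4)cc3)c3[nH]nc(C(C)C)c3n2)cc1`) gives 3950 nM as the higher of the two numbers, which makes it the weaker inhibitor. For the measured compounds named here, the one measured step is a 63-fold higher number from compound 1 to compound 2 (1.80 log units; beyond the scatter) and it came with 4-methoxyphenyl in place of aminomethyl. Compound 3 (`CC(C)c1n[nH]c2c(NCc3ccc(-c4ccccn4)cc3)nc(NCc3ccc(-c4ccccn4)cc3)nc12`) differs from compound 2 by pyridin-2-yl in place of methoxy on an aromatic carbon. Going by the values given here, no measured step covers this exact change, so that large step bears on it only indirectly. Compound 3 lacks the aminomethyl of compound 1 (63 nM) and so no return towards that number is expected. No step beyond the scatter is expected in this assay in either direction. The estimated step is a 1.3-fold lower number from compound 2 to compound 3 (0.12 log units; within the scatter) in this expectation. Compound 3 is estimated at 3000 nM (expected range 800 nM to 11000 nM).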

Compound 3, half-maximal inhibitory concentration: 2540 nM
Compound 3: middle estimate off by 1.2-fold (0.07 log units), on the high side; low and high end bracket the measured number.
By their numbers in this assay, from the lowest: compound 1; then compounds 3 and 2 (each within the scatter of the next).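

In this assay the far end of the benzyl group on the aromatic ring takes a much larger substituent without a step beyond the scatter: a whole pyridin-2-yl ring in place of methoxy gives a 1.6-fold lower number from compound 2 to compound 3 (0.19 log units; within the scatter) as the change. So a second aryl end, 4-(pyridin-2-yl)phenyl in place of aminomethyl, also leaves the number far from that of compound 1, with a 40-fold higher number from compound 1 to compound 3 (1.61 log units; beyond the scatter) as the step, much as 4-methoxyphenyl did. No measurement at hand explains why these aromatic ends sit so far from aminomethyl.

As far as these compounds go, whether a longer chain such as aminopropyl, or a hydroxymethyl, in place of aminomethyl would stay close to compound 1 remains open. So does whether an amine on the outer aromatic ring of compound 3 would bring the number back down.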